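Bromo in place of methyl on compound 1

This account rests on a few compounds, and the source may have more. Where it says the series, first, only, none or still open, it means among the compounds named here.

compound 1 `Cc1ccc(-c2nnc(NC(=O)CCCCCCC(=O)NO)s2)o1`: 880 nM
compound 2 `CC(C)c1ccc(C(C)c2nnc(NC(=O)CCC(=O)NO)s2)cc1`: 14700 nM
compound 3 `Cc1ccc2c(c1)/C(=N\O)C(=O)N2CCCC(=O)NO`: 490 nM

All three numbers come from a functional assay on PC-3 cells (Homo sapiens) for inhibition, read by MTT assay; on this read-out higher numbers stand for weaker inhibition and lower numbers for stronger inhibition. Compound 1 at 880 nM sits level, within the usual scatter, with compound 3 at 490 nM. Compound 2 carries a clearly higher number, 14700 nM, which means much weaker inhibition than compound 1 shows.

The compound still to be measured is compound 4 `O=C(CCCCCCC(=O)Nc1nnc(-c2ccc(Br)o2)s1)NO`. It keeps the core of compound 1 and changes one group: bromo in place of methyl on an aromatic carbon. In words, this is bromo in place of methyl on an aromatic carbon, turning 5-methylfuran-2-yl into 5-bromofuran-2-yl.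

For the measured compounds named here, no two measured compounds differ in just one place, so the data offer no direct guide to this swap. Going by the values given here, the only anchor is compound 1 at 880 nM, so no shift beyond the scatter is expected in this assay, in either direction. The expected step of a 1.2-fold lower number from compound 1 to compound 4 (0.07 log units; within the scatter) stays small. Compound 4 is estimated at 750 nM, with an expected range of 300 nM to 1900 nM.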

Compound 4, half-maximal inhibitory concentration: 880 nM
Beside the measured number, compound 4's estimate is 1.2-fold (0.07 log units) below it; the measured number falls inside the stated range.
By their numbers in this assay, from the lowest: compounds 3, 1 and 4 (each within the scatter of the next); then compound 2.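

Bromo in place of methyl, on the carbon of the five-membered aromatic ring next to the ring oxygen, gives in this assay no change at the digits printed from compound 1 to compound 4 (within the scatter). For the compounds shown here, this is the first pair here that differs in one place only, so it offers the first direct reading of this position: the assay does not separate these two groups, at least on this core and with this chain. Nothing available explains why the two groups read alike.

As far as these compounds go, one swap cannot show how much freedom this carbon allows, so it remains open whether an amine, a carboxylic acid or a phenyl ring there would move the number beyond the scatter. From the compounds shown here alone, it also remains open whether bromo and methyl would still read alike with a longer chain.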